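Ester side chain variation on the shared crown ether core

The compounds below may be only part of what the source reports. "The series", "measured", "known", "first", "only" and "open" are said of these compounds alone.

Measured so far in a functional assay on WiDr cells (Homo sapiens) for inhibition, read by sulforhodamine B assay, with a stated time of 48 h; a lower number here means a stronger inhibitor of growth, a higher number a weaker inhibitor of growth:
compound 1 `O=C(CCCCCc1ccccc1)OCC1COCCOCCOCCOCCOCCO1` gives > 100000 nM, which is a limit of the assay.
compound 2 `CC(C)=CC1C(C(=O)OCC2COCCOCCOCCOCCOCCO2)C1(C)C` gives 56000 nM.
compound 3 `O=C(CCCCCCCCCCOc1ccccc1)OCC1COCCOCCOCCOCCOCCO1` gives 66000 nM.

Compound 1 stands at the limit of > 100000 nM in this assay, at which 1 of the 3 values shown sits, so only a limit and no number is known for it. The steps away from it, an at least 1.7-fold lower number from compound 1 to compound 2 (0.25 log units; that floor lies within the scatter) and an at least 1.5-fold lower number from compound 1 to compound 3 (0.18 log units; that floor lies within the scatter), are floors only and lie within the scatter, so they give no direction. Compound 4 `O=C(CCCCC1CCCCC1)OCC1COCCOCCOCCOCCOCCO1` differs from compound 1 by cyclohexyl in place of benzyl on a saturated chain carbon, four bonds along the chain from a carbonyl carbon. Among the measured compounds shown here, no measured step covers this change; both measured steps exchange other parts of the ester chain. The step expected is a number no higher from compound 1 to compound 4 (the limit leaves the size open). Compound 4 is therefore estimated at 100000 nM, between 40000 nM and 250000 nM, with a limit rather than a number quite possible.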

Compound 4, concentration for 50% growth inhibition: 33000 nM
Compound 4: the middle estimate sits 3.0-fold (0.48 log units) above what was measured; the whole stated range lies above it.
By their numbers in this assay, from the lowest: compounds 4, 2 and 3 (each within the scatter of the next). At a limit, above all of these: compound 1.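

In this assay, cyclohexyl in place of benzyl on a saturated chain carbon, four bonds along the chain from a carbonyl carbon, gives the first step away from compound 1 that lies beyond the scatter (an at least 3.0-fold lower number from compound 1 to compound 4 (0.48 log units; beyond the scatter)). As far as these compounds go, the true size of this change stays unknown, and only a floor can be read: the limit of > 100000 nM in this assay, at which 1 of the 4 values shown sits. The other new step (a 1.7-fold lower number from compound 2 to compound 4 (0.23 log units; within the scatter)) gives no order.

Still open, from the compounds shown here alone, is whether a longer chain ending in cyclohexyl would change the number. An amine or a carboxylic acid at the chain end is equally untested in the compounds shown.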